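Two cytotoxicity limits and an untested cyclopropyl analogue

A few compounds are considered here, and "the series" means these few. Any claim that something is new, unique, unknown or untested is made for them only; others in the source may bear on it.

Compound 1 `CC(C)n1ncc2c(C(=O)Nc3ccc(F)cc3)cc(-c3ccco3)nc21` gives in an ADME assay on LLC-MK2 cells (Macaca mulatta) for cytotoxicity, read by spectrophotometry and crystal violet staining, with a stated time of 4 days; on this read-out higher numbers stand for lower toxicity in this test and lower numbers for higher toxicity in this test > 200000 nM, which is a limit of the assay and not a number.
Compound 2 `CC(C)n1ncc2c(C(=O)Nc3ccc(F)c(F)c3)cc(-c3cccs3)nc21` gives in this assay > 200000 nM, likewise a limit.

Among the compounds with values here, compound 1 therefore stands at the limit of > 200000 nM in this assay, at which 2 of the 2 values shown sit, with no measured concentration behind it, and no step between measured compounds exists. Compound 3 `CC(C)n1ncc2c(C(=O)Nc3ccc(F)cc3)cc(C3CC3)nc21` differs from compound 1 by cyclopropyl in place of furan-2-yl on an aromatic carbon. No step beyond the usual scatter is expected in this assay, in either direction. Compound 3 is estimated to give 200000 nM in this assay, in the range 100000 nM to 400000 nM. That estimate for compound 3 means a number no higher from compound 1 to compound 3 (the limit leaves the size open), expected to stay within the scatter and most likely reported again as a limit.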

Compound 3, half-maximal cytotoxic concentration: 12500 nM
Compound 3: the middle estimate sits 16-fold (1.20 log units) above what was measured; the whole stated range lies above it.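

Cyclopropyl in place of furan-2-yl, on the aromatic carbon next to the ring nitrogen, gives in this assay an at least 16-fold lower number from compound 1 to compound 3 (1.20 log units; beyond the scatter), a change toward higher toxicity in this test. The group at this place therefore matters to this read-out, which the two earlier limits could not show. Compound 3 alone has a measured concentration rather than a limit: the limit of > 200000 nM in this assay, at which 2 of the 3 values shown sit.

Going by these compounds, the full size of the step stays open, as its starting value is a limit. Also open, on these data alone, is what a phenyl ring or an amine at this place would give.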